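A few compounds are considered here, and "the series" means these few. Any claim that something is new, unique, unknown or untested is made for them only; others in the source may bear on it.

Of the compounds shown here, two have so far been measured in an assay on isolated protein for inhibition of Dihydrofolate reductase (Mus musculus), at pH 7.20; a lower number here means a less potent compound, a higher number a more potent compound, by a factor of ten per unit of this negative logarithm. Compound 1 `CSc1ccccc1N1C(N)=NC(N)=NC1(C)C` gives 2.48 in this assay, and compound 2 `CCc1ccccc1N1C(N)=NC(N)=NC1(C)C` gives 3.38. Going by the values given here, the single step between them, a number 0.90 log units higher from compound 1 to compound 2 (beyond the scatter), is the only comparison on hand. Compound 2 therefore stands at the top of the two numbers, with compound 1 as its nearest neighbour, lying beyond the scatter below it.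

Compound 3 `CC1(C)N=C(N)N=C(N)N1c1ccccc1Cl` has not yet been measured. It differs from compound 2 in one place: chloro in place of ethyl on an aromatic carbon. Among the compounds with values here, no measured step involves a chloro group, so the one recorded step, from methylsulfanyl to ethyl, bears on it only indirectly: it shows that exchanging the group on this aromatic carbon can move the number by a modest amount, but gives no indication of which way chloro would go. For compound 3 the expectation is therefore a step of a number 0.12 log units higher from compound 2 to compound 3 (within the scatter) in this assay, which is no movement beyond the scatter. Compound 3 is accordingly estimated at 3.5 in this assay, with a range from 2.7 to 4.3.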

Compound 3, logarithm of the reciprocal of the active concentration, log(1/C): 4.72
Estimate against measurement, compound 3: 1.22 log units below; measured number above the stated range.
By their numbers in this assay, from the lowest: compound 1; then compound 2; then compound 3.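

In this assay, chloro in place of ethyl on this aromatic carbon, ortho to a large group, gives a number 1.34 log units higher from compound 2 to compound 3 (beyond the scatter) and is a large change, while chloro in place of methylsulfanyl gives a number 2.24 log units higher from compound 1 to compound 3 (beyond the scatter) and is larger still. The earlier pair showed only a modest movement at this position, whereas these steps show that the group held there can shift the number much further, and that a single chlorine atom can stand above the two-carbon ethyl group it replaces. With both of its steps beyond the scatter, compound 3 is the most potent of the three, but nothing at hand offers a measured reason for that standing.

The three compounds leave open whether chloro is a special case or one point on a wider trend, which bromo, fluoro or methoxy at the same place would begin to test. They also leave open how an amine, a carboxylic acid or a longer chain such as propyl would fall against these values.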